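The source may hold more compounds than are shown below. What is called first, only, known or untested is meant among the compounds shown, and "the series" means these compounds.

In a functional assay on HeLa cells (Homo sapiens) for inhibition (a higher number here means a weaker inhibitor, a lower number a stronger inhibitor), compound 1 (`CN(C(=O)CC(CC(=O)NCCN1CCCC1)c1ccccc1)C1Cc2ccccc2C1`) reads > 100000 nM, which is a limit of the assay and not a number. Compound 2 (`CCNCCNC(=O)CC(CC(=O)N(CC)C1Cc2ccccc2C1)c1ccccc1`) reads > 100000 nM, also only a limit. Both compounds therefore stand at the limit of > 100000 nM in this assay, at which 2 of the 2 values shown sit. Compound 3 (`CCN(C(=O)CC(CC(=O)NCCN1CCCC1)c1ccccc1)C1Cc2ccccc2C1`) carries pyrrolidin-1-yl in place of ethylamino on a saturated chain carbon, two bonds along the chain from an amide-type nitrogen. The expected a number no higher from compound 2 to compound 3 (the limit leaves the size open) is none beyond the scatter in this assay, and another limit is the likely report. For compound 3 the expected value is 100000 nM, with an estimated range of 40000 nM to 200000 nM.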

Compound 3, half-maximal inhibitory concentration: > 100000 nM
Compound 3: a limit, no number (the forecaster's own chance of this, stated with the estimate: 85%); the middle value sits exactly at the limit.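

In this assay no step can be read among compound 1, compound 2 and compound 3, since each gives only a limit: the limit of > 100000 nM in this assay, at which 3 of the 3 values shown sit.

The compounds shown leave open what number any of the three would give, and so the size of either change.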